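Two assay limits and one new aryl arm

This account rests on a few compounds, and the source may have more. Where it says the series, first, only, none or still open, it means among the compounds named here.

compound 1 `COc1cc(-c2ccnc3cc(-c4ccc(C(C)(C)C)cc4)nn23)cc(OC)c1OC`: > 10000 nM in a functional assay on B16-F0 cells (Mus musculus) for inhibition, read by CCK-8 assay, with a stated time of 48 h; a lower number here means a stronger inhibitor, a higher number a weaker inhibitor
compound 2 `Cc1ccc(-c2cc3nccc(-c4ccc(F)cc4)n3n2)cc1`: > 10000 nM in this assay

The value of compound 1 is a limit of this assay, not a number. The value of compound 2 is likewise a limit. Within the data shown here, compound 1 therefore stands at the limit of > 10000 nM in this assay, at which 2 of the 2 values shown sit, and no measured step between compounds exists. Compound 3 `COc1cc(-c2ccnc3cc(-c4ccc5cnn(C)c5c4)nn23)cc(OC)c1OC` differs from compound 1 by 1-methyl-1H-indazol-6-yl in place of 4-(tert-butyl)phenyl on an aromatic carbon. Nothing measured supports a shift, so in this assay the expected step is an at least 1.1-fold lower number from compound 1 to compound 3 (0.04 log units; that floor lies within the scatter), none beyond the scatter. Compound 3 is estimated at 9000 nM, within 1500 nM to 40000 nM, most likely reported again as a limit.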

Compound 3, half-maximal inhibitory concentration: 1000 nM
Compound 3: the middle estimate sits 9.0-fold (0.95 log units) above what was measured; the measured number lies below the stated range.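

This aryl position on the shared core tolerates a change that brings measurable activity in this assay: 1-methyl-1H-indazol-6-yl in place of 4-(tert-butyl)phenyl gives an at least 10-fold lower number from compound 1 to compound 3 (1.00 log units; beyond the scatter). Both groups hold 10 heavy atoms, so the step comes without a change in that count. Compound 1 stands at a limit, so the full size of the step cannot be read: the limit of > 10000 nM in this assay, at which 2 of the 3 values shown sit.

Open, on these data alone, is whether the step depends on the ring nitrogens, the fused ring or the methyl group. A naphthyl or an unmethylated 1H-indazol-6-yl at this position would separate these.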